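Methoxy on the phenyl of compound 2: cytotoxicity expected unchanged

A few compounds are considered here, and "the series" means these few. Any claim that something is new, unique, unknown or untested is made for them only; others in the source may bear on it.

Measured compounds:
compound 1, `CCOC(=O)c1cc2ccc(OCCCn3cc(CNC(=O)CCCCC4CCSS4)nn3)cc2oc1=O`, 32.4% in a functional assay on PC-12 cells (Rattus norvegicus) for cytotoxicity, read by MTT assay, with stated times of 3 h and 2 h, tested at 5 uM; a higher number here means a stronger effect of the compound at the concentration tested, a lower number a weaker effect
compound 2, `O=C(CCCCC1CCSS1)NCc1cn(CCCOc2ccc3cc(-c4ccccc4)c(=O)oc3c2)nn1`, 29.8% in this assay

Compound 2 stands with the lowest of the two numbers in this assay, but its nearest neighbour, compound 1, sits only a number 2.6 percentage points lower from compound 1 to compound 2 (within the scatter), a step that falls within the scatter and so tells of no real difference between the two.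

Compound 3, `COc1ccc(-c2cc3ccc(OCCCn4cc(CNC(=O)CCCCC5CCSS5)nn4)cc3oc2=O)cc1`, has not yet been tested. It differs from compound 2 in one place: methoxy in place of hydrogen on an aromatic carbon.

Among the measured compounds shown here, no measured step touches a methoxy group; the only step known, from compound 1 to compound 2, changed a different group and was small. With nothing to suggest movement, compound 3 is expected to sit near compound 2, with a step of a number 0.2 percentage points higher from compound 2 to compound 3 (within the scatter) in this assay. The estimate for compound 3 in this assay is 30%, within a range of 18% to 42%.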

Compound 3, a percentage reported as activity, at one concentration (the size of the read-out at that concentration, not a potency): 52.8%
Compound 3: middle estimate off by 22.8 percentage points, on the low side; measured number above the stated range.
By their numbers in this assay, from the lowest: compounds 2 and 1 (each within the scatter of the next); then compound 3.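

The phenyl ring of compound 2 turns out to be a responsive place: in this assay, adding a methoxy group para to the large group gives a step of a number 23 percentage points higher from compound 2 to compound 3 (beyond the scatter), whereas the earlier change of ethoxycarbonyl to phenyl gave only a number 2.6 percentage points lower from compound 1 to compound 2 (within the scatter). The change of ethoxycarbonyl to 4-methoxyphenyl likewise gives a number 20.4 percentage points higher from compound 1 to compound 3 (beyond the scatter), so this aromatic carbon can separate the compounds once the phenyl carries the methoxy group. Nothing available explains the rise.

The compounds shown leave open whether the rise is particular to methoxy or would also come with a hydroxyl group, a chlorine atom or a longer ethoxy group at the same carbon. They also leave open what a methoxy group would do elsewhere on the phenyl ring.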